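Swapping 2-methylphenyl for 3-methylphenyl in compound 3

A few compounds are considered here, and "the series" means these few. Any claim that something is new, unique, unknown or untested is made for them only; others in the source may bear on it.

Values measured so far in a physicochemical assay for metabolic stability, read by HPLC, in phosphate buffer, at pH 7.4, tested at 10 uM (on this read-out lower numbers stand for a shorter-lived compound and higher numbers for a longer-lived compound), are these
- compound 1 `Cc1cccc(CNC(=O)n2cnc3ccccc32)c1` gives 0.933 h here
- compound 2 `Cc1ccccc1CNC(=O)n1cnc2ccccc21` gives 0.967 h here
- compound 3 `Cc1ccccc1CNC(=O)n1c(N)nc2ccccc21` gives 0.167 h here

Compound 3 holds the lowest of the three numbers, and its gaps to compound 1 and to compound 2 both lie beyond the usual scatter. The next compound to be measured is compound 4 `Cc1cccc(CNC(=O)n2c(N)nc3ccccc32)c1` which has the same atoms as compound 3, joined differently. The change is this: 3-methylphenyl in place of 2-methylphenyl on a saturated chain carbon bound to an amide-type nitrogen and the rest of the molecule stays the same.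

Among the measured compounds shown here, only one measured step exists, a 5.8-fold lower number from compound 2 to compound 3 (0.76 log units; beyond the scatter) and it is a different change, amino in place of hydrogen on an aromatic carbon. Compound 3 and compound 4 both keep that amino group, so a step of that size is not expected here. The closest guide is that compound 1 at 0.933 h and compound 2 at 0.967 h lie within the usual scatter of each other. For the measured compounds named here, no measured pair shows what the present change does when the amino group is there, so some uncertainty remains. The expected result is a 1.0-fold higher number from compound 3 to compound 4 (0.01 log units; within the scatter) with no move beyond the scatter expected. The estimate for compound 4 is 0.17 h with an expected range from 0.09 h to 0.33 h in this measurement.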

Compound 4, half-life: 0.183 h
Compound 4: the middle estimate sits 1.1-fold (0.03 log units) below what was measured, within the range that was stated.
By their numbers in this assay, from the lowest: compounds 3 and 4 (each within the scatter of the next); then compounds 1 and 2 (each within the scatter of the next).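

In this assay, 3-methylphenyl in place of 2-methylphenyl on a saturated chain carbon bound to an amide-type nitrogen gives a 1.1-fold higher number from compound 3 to compound 4 (0.04 log units; within the scatter), so this swap leaves the half-life within the scatter when the amino group is present, just as compound 1 at 0.933 h and compound 2 at 0.967 h lie within the scatter of each other without it. The amino group now has a second measured step, a 5.1-fold lower number from compound 1 to compound 4 (0.71 log units; beyond the scatter), which points the same way as a 5.8-fold lower number from compound 2 to compound 3 (0.76 log units; beyond the scatter), so the shorter half-life appears with both methylphenyl groups rather than with only one of them. No measurement at hand explains the effect of either change on the half-life.

The compounds shown leave open whether a methylamino or hydroxyl group in place of the amino group would also give a shorter half-life in this assay. They also leave open whether a methoxy or chloro group in place of the methyl, or a longer chain in place of the saturated chain carbon, would change the number beyond the scatter.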